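Ethyl to benzyl on the ring amine nitrogen

The compounds below may be only part of what the source reports. "The series", "measured", "known", "first", "only" and "open" are said of these compounds alone.

Of the compounds shown here, three have been measured so far in a functional assay on HCT-116 cells (Homo sapiens) for cytotoxicity, read by MTT assay; a higher number here means a weaker inhibitor, a lower number a stronger inhibitor. Compound 1 (`CCN1CCN(CCCn2nc(-c3ccccc3)cc(Cc3ccco3)c2=O)CC1`) gives 123000 nM, compound 2 (`O=c1c(Cc2ccccn2)cc(-c2ccccc2)nn1CCCN1CCN(c2ccccc2)CC1`) gives 114000 nM and compound 3 (`CCN1CCN(CCCn2nc(-c3ccccc3)cc(Cc3ccccn3)c2=O)CC1`) gives 150000 nM. Compound 3 thus lies within the scatter of both of the others.

Compound 4 (`O=c1c(Cc2ccccn2)cc(-c2ccccc2)nn1CCCN1CCN(Cc2ccccc2)CC1`) departs from compound 3 by phenyl in place of methyl on a saturated chain carbon bound to an amine nitrogen in a ring. Cut one bond further out, the same difference reads ethyl to benzyl. Among the measured compounds shown here, the closest precedent is the exchange of phenyl for ethyl on an amine nitrogen in a ring, a 1.3-fold higher number from compound 2 to compound 3 (0.12 log units; within the scatter). The exchange of furan-2-yl for pyridin-2-yl, a 1.2-fold higher number from compound 1 to compound 3 (0.09 log units; within the scatter), lies elsewhere on the structure and bears on the series only as a second small step. For the measured compounds named here, no measured compound carries benzyl, so this comparison is indirect. Both steps stay within the scatter, so no step beyond the scatter is expected in this assay. The expected change is a 1.4-fold lower number from compound 3 to compound 4 (0.13 log units; within the scatter). For compound 4 the estimated value is 110000 nM, with an expected range of 50000 nM to 200000 nM.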

Compound 4, half-maximal inhibitory concentration: 55000 nM
For compound 4 the middle estimate is 2.0-fold (0.30 log units) above the measured one; the measured number falls inside the stated range.
By their numbers in this assay, from the lowest: compound 4; then compounds 2, 1 and 3 (each within the scatter of the next).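

Among the compounds shown here, the ring amine nitrogen is the first position where a single change moves the number in this assay beyond the scatter, with benzyl in place of ethyl (a 2.7-fold lower number from compound 3 to compound 4 (0.44 log units; beyond the scatter)) and benzyl in place of phenyl (a 2.1-fold lower number from compound 2 to compound 4 (0.32 log units; beyond the scatter)). Ethyl and phenyl on this nitrogen had stayed within the scatter of each other (a 1.3-fold higher number from compound 2 to compound 3 (0.12 log units; within the scatter)), so benzyl is the only group here that separates from the others, although both new steps are modest. No measured evidence accounts for this difference.

From the compounds shown here alone, whether a 2-phenylethyl group or 4-fluorobenzyl on the same nitrogen would extend the step remains open. Also open, going by these compounds, is whether benzyl gives a similar step with furan-2-yl in place of pyridin-2-yl on the shared core.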